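The compounds below may be only part of what the source reports. "The series", "measured", "known", "first", "only" and "open" are said of these compounds alone.

Measured compounds:
Compound 1 `CCc1nc2c(C)cc(C)nc2n1Cc1ccc(OC(C(=O)O)c2ccccc2C)cc1` gives 5200 nM
Compound 2 `CCc1cc(Cn2c(CC)nc3c(C)cc(C)nc32)ccc1OC(C(=O)O)c1ccccc1` gives 410 nM

Within the data shown here, in an assay on Midbrain with Type-2 angiotensin II receptor (Rattus norvegicus) as the target (on this read-out higher numbers stand for weaker inhibition and lower numbers for stronger inhibition), compound 2 stands at the lowest of the two numbers measured so far. Its nearest neighbour is compound 1, whose number is higher by a margin that lies beyond the usual scatter, so compound 2 is the stronger inhibitor of the pair. Compound 3 `CCc1nc2c(C)cc(C)nc2n1Cc1ccc(OC(C(=O)O)c2ccccc2)c(OC)c1` has not yet been measured in this assay. It differs from compound 2 in one place: methoxy in place of ethyl on an aromatic carbon. The two groups are of the same size in heavy atoms, but the incoming one brings a hydrogen-bond acceptor where the ethyl had none. Among the measured compounds shown here, no measured pair shows this exchange, so there is no direct precedent for the size of the step in this assay. The exchange keeps the overall shape of compound 2, and a step of modest size is expected, with a somewhat higher number somewhat more likely than a lower one. Compound 3 is therefore estimated at 800 nM, with a range from 200 nM to 3200 nM, which means an expected step of a 2.0-fold higher number from compound 2 to compound 3 (0.29 log units; within the scatter).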

Compound 3, half-maximal inhibitory concentration: 2900 nM
For compound 3 the middle estimate is 3.6-fold (0.56 log units) below the measured one; the range from low to high includes it.
By their numbers in this assay, from the lowest: compound 2; then compounds 3 and 1 (each within the scatter of the next).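

In this assay, methoxy in place of ethyl, on the aromatic carbon ortho to a carboxy(phenyl)methoxy group, gives a 7.1-fold higher number from compound 2 to compound 3 (0.85 log units; beyond the scatter) and so moves the pair towards weaker inhibition. Among these compounds, this is the first pair that differs in one place, and it shows that the read-out responds to what sits at this carbon even when the incoming and outgoing groups are equal in heavy atoms, the exchange replacing one carbon with an oxygen and adding one hydrogen-bond acceptor. Nothing at hand explains the size of this step, so a single exchange cannot separate the role of the oxygen from that of the lost carbon.

The compounds shown leave open how a hydroxyl group, a chlorine atom or a longer chain such as propyl would behave at this carbon, and so whether ethyl is unusually favourable here or methoxy unusually unfavourable. They also leave open whether the same exchange would produce a step of similar size in a compound carrying the extra methyl on the phenyl ring of the acid side chain, as compound 1 does.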